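This account rests on a few compounds, and the source may have more. Where it says the series, first, only, none or still open, it means among the compounds named here.

Of the compounds shown here, three built on one shared core have been measured in a functional assay on KBVIN cells (Homo sapiens) for antiproliferative activity, read by sulforhodamine B assay, with a stated time of 3 days; on this read-out lower numbers stand for an effect already at smaller amounts and higher numbers for an effect only at larger amounts of compound. Compound 1 `CCCCc1ccc(-c2cc(=O)c3c(o2)C(CC)(CC)C(=O)C(CC)=C3O)cc1` gives 37 uM, compound 2 `CCC1=C(O)c2c(oc(-c3ccc(O)cc3)cc2=O)C(CC)(CC)C1=O` gives 20.6 uM, and compound 3 `CCC1=C(O)c2c(oc(-c3ccc(OC(F)(F)F)cc3)cc2=O)C(CC)(CC)C1=O` gives 9.95 uM. For the measured compounds named here, compound 2 stands second highest of these three numbers: its nearest neighbour is compound 1, which lies within the scatter of it, and the step of a 2.1-fold lower number from compound 2 to compound 3 (0.32 log units; beyond the scatter) is the only one from compound 2 that lies beyond the scatter.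

The compound now in question is compound 4 `CCC1=C(O)c2c(oc(-c3cccc(F)c3)cc2=O)C(CC)(CC)C1=O`, which differs from compound 2 in one place: 3-fluorophenyl in place of 4-hydroxyphenyl on an aromatic carbon, on the aromatic carbon next to the ring oxygen of the shared core. Going by the values given here, none of the measured steps makes this exact change. Among the compounds with values here, the steps that bear on it all alter the group carried by the same phenyl ring: a 1.8-fold lower number from compound 1 to compound 2 (0.25 log units; within the scatter), a 3.7-fold lower number from compound 1 to compound 3 (0.57 log units; beyond the scatter) and a 2.1-fold lower number from compound 2 to compound 3 (0.32 log units; beyond the scatter). All three measured numbers sit in a narrow band, and the largest of these steps is only modest. Compound 4 is therefore expected to fall in that same band, with no confident direction in this assay. The estimate for compound 4 is 15 uM, within a range from 6 uM to 40 uM. For compound 4 this estimate means an expected step of a 1.4-fold lower number from compound 2 to compound 4 (0.14 log units; within the scatter), which should stay within the scatter.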

Compound 4, concentration for half-maximal effect: 3.09 uM
Compound 4: the middle estimate sits 4.9-fold (0.69 log units) above what was measured; measured number outside the range, below it.
By their numbers in this assay, from the lowest: compound 4; then compound 3; then compounds 2 and 1 (each within the scatter of the next).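

In this assay the exchange of 4-hydroxyphenyl for 3-fluorophenyl on the aromatic carbon next to the ring oxygen gives a 6.7-fold lower number from compound 2 to compound 4 (0.82 log units; beyond the scatter) and takes compound 4 out of the narrow band held by compounds 1, 2 and 3. Among those three compounds the widest step was a 3.7-fold lower number from compound 1 to compound 3 (0.57 log units; beyond the scatter) and so the group on this phenyl ring can move the number further than the earlier compounds showed, with compound 4 now at the lowest number of the four. Nothing available here says what lies behind this step.

Two things change at once in this step, the group on the phenyl ring and its place on that ring, and the compounds shown do not separate them: neither 4-fluorophenyl nor 3-hydroxyphenyl stands among them. They also leave open how other groups would behave in the place the fluorine holds in compound 4, such as a chlorine, a methoxy or an amine, and whether a second fluorine on the same ring would add to the result.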